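The source may report more compounds than this note shows. Statements on the series, on what has been measured and on what is new or still open speak of the compounds shown alone.

The measured compounds:

Compound 1 `COc1ccc(-c2cc3nccc(-c4cc(OC)c(OC)c(OC)c4)n3n2)cc1N`: in a functional assay on B16-F0 cells (Mus musculus) for inhibition, read by CCK-8 assay, with a stated time of 48 h (on this read-out higher numbers stand for weaker inhibition and lower numbers for stronger inhibition), compound 1 gives 88 nM.
Compound 2 `COc1cc(-c2ccnc3cc(-c4ccccc4)nn23)cc(OC)c1OC`: compound 2 gives 4730 nM.
Compound 3 `COc1ccc(-c2cc3nccc(-c4cc(OC)c(OC)c(OC)c4)n3n2)cc1`: compound 3 gives 1410 nM.

Compound 1 stands lowest of the three numbers; its nearest neighbour is compound 3, reached by a 16-fold higher number from compound 1 to compound 3 (1.20 log units; beyond the scatter), and the furthest is compound 2, reached by a 54-fold higher number from compound 1 to compound 2 (1.73 log units; beyond the scatter). Compound 4 `COc1cc(-c2ccnc3cc(-c4cn(C)c5ccccc45)nn23)cc(OC)c1OC` has not yet been measured. It differs from compound 1 in one place: 1-methyl-1H-indol-3-yl in place of 3-amino-4-methoxyphenyl on an aromatic carbon. Among the measured compounds shown here, two measured steps bear on this change, since both remove the amino group from the group that leaves: a 16-fold higher number from compound 1 to compound 3 (1.20 log units; beyond the scatter), and a 54-fold higher number from compound 1 to compound 2 (1.73 log units; beyond the scatter), where the whole 3-amino-4-methoxyphenyl is exchanged for a plain phenyl. Both are large steps towards weaker inhibition in this assay. The incoming 1-methyl-1H-indol-3-yl carries no hydrogen-bond donor, so a large step in the same direction is expected, roughly a 23-fold higher number from compound 1 to compound 4 (1.36 log units; beyond the scatter). Compound 4 is therefore estimated at 2000 nM, with a range from 500 nM to 8000 nM.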

Compound 4, half-maximal inhibitory concentration: 185 nM
Compound 4: the middle estimate sits 11-fold (1.03 log units) above what was measured, and the stated range ends above it.
By their numbers in this assay, from the lowest: compound 1; then compound 4; then compound 3; then compound 2.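

In this assay, the result shows that this aromatic carbon tolerates a group with 0 hydrogen-bond donors: exchanging 3-amino-4-methoxyphenyl for 1-methyl-1H-indol-3-yl costs only a modest step, a 2.1-fold higher number from compound 1 to compound 4 (0.32 log units; beyond the scatter). The same incoming group also gives far lower numbers than the two other groups without an amino group, with a 7.6-fold lower number from compound 3 to compound 4 (0.88 log units; beyond the scatter) and a 26-fold lower number from compound 2 to compound 4 (1.41 log units; beyond the scatter), so compound 4 goes against the link between losing the amino group and weak inhibition that compound 2 and compound 3 had suggested. No measurement at hand explains why the 1-methyl-1H-indol-3-yl does so well here.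

The compounds shown leave open whether this gain belongs to the fused ring pair or to its methyl. A 1H-indol-3-yl or a naphthyl at the same carbon would separate those two readings.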